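Changing the amide nitrogen group of compound 2

The source may report more compounds than this note shows. Statements on the series, on what has been measured and on what is new or still open speak of the compounds shown alone.

Compound 1 `C=C(CC)C(=O)c1ccc(OCC(=O)Nc2ccc3nc[nH]c3c2)c(Cl)c1Cl`: 3200 nM
Compound 2 `C=C(CC)C(=O)c1ccc(OCC(=O)NCCO)c(Cl)c1Cl`: > 25000 nM

In a functional assay on CLL cells (Homo sapiens) for cytotoxicity, read by MTT assay, with a stated time of 48 h (on this read-out higher numbers stand for an effect only at larger amounts of compound and lower numbers for an effect already at smaller amounts), compound 1 gives a measured number. For compound 2, > 25000 nM is only a limit of the assay, not a number. Compound 3 `C=C(CC)C(=O)c1ccc(OCC(=O)NO)c(Cl)c1Cl` has hydroxy in place of 2-hydroxyethyl on an amide-type nitrogen. Among the compounds with values here, the one measured change at this nitrogen is an at least 7.8-fold higher number from compound 1 to compound 2 (0.89 log units; beyond the scatter), and it brings in a different group, so it guides only loosely. Compound 2 stands at the limit of > 25000 nM, so a modest move to a lower number is expected. The expected step is an at least 3.1-fold lower number from compound 2 to compound 3 (0.49 log units; beyond the scatter). For compound 3 the estimated value is 8000 nM, with an expected range of 2000 nM to 25000 nM.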

Compound 3, half-maximal effective concentration: 4500 nM
Compound 3: the middle estimate sits 1.8-fold (0.25 log units) above what was measured, and the stated range covers the measured number.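

Replacing 2-hydroxyethyl with hydroxy on this amide nitrogen brings the effect back into the measurable range, with an at least 5.5-fold lower number from compound 2 to compound 3 (0.74 log units; beyond the scatter). This size is only a minimum, since compound 2 has a limit and not a number: the limit of > 25000 nM in this assay, at which 1 of the 3 values shown sits. Hydroxy and 1H-benzimidazol-6-yl give values within the scatter of each other, with a 1.4-fold higher number from compound 1 to compound 3 (0.15 log units; within the scatter), so among these compounds a ring on this nitrogen is not needed for an effect of this size.

Going by these compounds, what a methoxy or a methyl group on this nitrogen would give stays open. Why 2-hydroxyethyl falls behind both other groups also stays open.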